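A few compounds are considered here, and "the series" means these few. Any claim that something is new, unique, unknown or untested is made for them only; others in the source may bear on it.

Compound 1 `COc1ccc(Oc2ccc([N+](=O)[O-])cc2-c2ccsc2S(=O)(=O)N2CCN(C(=S)Nc3ccc(Cl)cc3)CC2)cc1OC`: > 50000 nM
Compound 2 `COc1cccc(NC(=O)NCCNS(=O)(=O)c2ccc(-c3ccccc3OCc3ccccc3)s2)c1`: > 50000 nM
Compound 3 `COc1ccc(NC(=S)NCCNS(=O)(=O)c2sccc2-c2ccc(C)cc2Oc2ccc(O)c(O)c2)cc1`: > 20000 nM

In a functional assay on HeLa cells (Homo sapiens) for inhibition, read by CCK-8 assay, with a stated time of 48 h (on this read-out higher numbers stand for weaker inhibition and lower numbers for stronger inhibition), compound 2 gives > 50000 nM, which is a limit of the assay and not a number. Compound 1 gives > 50000 nM, the same limit. Compound 3 gives > 20000 nM, which is also a limit. Within the data shown here, no measured compound here therefore has an exact value, and no measured pair shows how large a single structural change can be.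

Compound 4 `O=C(NCCNS(=O)(=O)c1ccc(-c2ccccc2OCc2ccccc2)s1)Nc1cccc([N+](=O)[O-])c1` keeps the structure of compound 2 except for one group: nitro in place of methoxy on an aromatic carbon. In words, nitro takes the place of methoxy on an aromatic carbon, turning the 3-methoxyphenyl group into a 3-nitrophenyl group.

Among the measured compounds shown here, with no measured step to guide the estimate, a number no higher from compound 2 to compound 4 (the limit leaves the size open) is expected to be none beyond the scatter in this assay. Compound 4 is expected to give about 50000 nM, with an estimated range of 20000 nM to 100000 nM.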

Compound 4, half-maximal inhibitory concentration: > 20000 nM
Compound 4: no number, only a limit (the forecaster's own chance of this, stated with the estimate: 75%); the middle value does not contradict the limit.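

No step can be read from compound 2 to compound 4: each gives only a limit, not a number. The compounds shown leave open how strongly any of them inhibits, and whether nitro in place of methoxy on an aromatic carbon changes that at all.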